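Ring-nitrogen substituent variation: compound 3 to compound 4

A few compounds are considered here, and "the series" means these few. Any claim that something is new, unique, unknown or untested is made for them only; others in the source may bear on it.

Measured so far in a functional assay on MGC-803 cells (Homo sapiens) for antiproliferative activity, read by CCK-8 assay, with a stated time of 72 h, tested at 2 uM; a higher number here means a stronger effect of the compound at the concentration tested, a lower number a weaker effect:
compound 1 `Nc1ccccc1NC(=O)c1ccc(CSC(=S)N2CCN(C3CCCCC3)CC2)cc1` gives 16.9%
compound 2 `Nc1ccccc1NC(=O)c1ccc(CSC(=S)N2CCN(Cc3ccncc3)CC2)cc1` gives 18.4%
compound 3 `Nc1ccccc1NC(=O)c1ccc(CSC(=S)N2CCN(Cc3ccccc3)CC2)cc1` gives 18.1%

Compound 3 stands second highest of the three numbers, but all three lie within the scatter of one another. The three steps among them, a number 1.5 percentage points higher from compound 1 to compound 2 (within the scatter), a number 1.2 percentage points higher from compound 1 to compound 3 (within the scatter) and a number 0.3 percentage points lower from compound 2 to compound 3 (within the scatter), each alter only the group on the amine nitrogen in the ring, and none moves beyond the scatter.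

Compound 4 `Nc1ccccc1NC(=O)c1ccc(CSC(=S)N2CCN(c3ccccc3F)CC2)cc1` differs from compound 3 by 2-fluorophenyl in place of benzyl on an amine nitrogen in a ring. Within the data shown here, no measured step exchanges these two groups directly; the measured steps bear on it only as earlier exchanges at the same place, all within the scatter. The step is therefore expected to be a number 0.1 percentage points lower from compound 3 to compound 4 (within the scatter), nothing beyond the scatter. Compound 4 is estimated at 18%, with a range from 8% to 28%.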

Compound 4, a percentage reported as inhibition, at one concentration (the size of the read-out at that concentration, not a potency): 33.7%
Estimate against measurement, compound 4: 15.7 percentage points below; the measured number lies above the stated range.
By their numbers in this assay, from the lowest: compounds 1, 3 and 2 (each within the scatter of the next); then compound 4.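

In this assay the amine nitrogen in the ring responds to its substituent after all: 2-fluorophenyl gives a number 15.6 percentage points higher from compound 3 to compound 4 (beyond the scatter) and a number 15.3 percentage points higher from compound 2 to compound 4 (beyond the scatter) and also a number 16.8 percentage points higher from compound 1 to compound 4 (beyond the scatter) while exchanges among cyclohexyl, benzyl and (pyridin-4-yl)methyl stayed within the scatter. Benzyl and 2-fluorophenyl have equal heavy-atom counts and one aromatic ring each, so these counts do not separate them. Nothing available explains this step.

The change alters both the link to the nitrogen and the ring substituent, so their shares remain unresolved. Plain phenyl or 2-chlorophenyl on this nitrogen would help separate them.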